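Chloro for fluoro on the open-chain amide

A few compounds are considered here, and "the series" means these few. Any claim that something is new, unique, unknown or untested is made for them only; others in the source may bear on it.

Compound 1 `O=C(CCC(=O)c1ccc(F)cc1)NCCCO` is the open-chain member of the set. In a functional assay on the whole organism with Mus musculus as the target (on this read-out higher numbers stand for an effect only at larger amounts of compound and lower numbers for an effect already at smaller amounts), compound 1 gives > 400 mg/kg, which is a limit of the assay and not a number; it sits at the limit of > 400 mg/kg in this assay, at which 1 of the 3 values shown sits. Compound 2 `O=C1CCCC2(c3ccccc3)OCCCN12` and compound 3 `O=C1CCC2(c3ccc(Cl)c(Cl)c3)OCCCN12` share a different core. In this assay compound 2 gives 122 mg/kg. In this assay compound 3 gives < 75 mg/kg, a limit of the assay, which is the limit of < 75 mg/kg in this assay, at which 1 of the 3 values shown sits. Among the measured compounds shown here, no pair of measured compounds here differs in one place only, so the change from compound 1 to compound 4 cannot be anchored to a measured step. Compound 4 `O=C(CCC(=O)c1ccc(Cl)cc1)NCCCO` differs from compound 1 by chloro in place of fluoro on an aromatic carbon. An exchange of one halogen for another at this place is expected to shift the read-out by no more than the usual scatter, in either direction. The step from compound 1 to compound 4 is therefore estimated as a step that the limit leaves unreadable from compound 1 to compound 4. Compound 4 is expected to give 500 mg/kg in this assay, within 150 mg/kg to 1500 mg/kg, and a report of only a limit is considered likely.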

Compound 4, dose for half-maximal effect: > 300 mg/kg
Compound 4: no number, only a limit (the forecaster's own chance of this, stated with the estimate: 70%); the middle value lies beyond the limit too.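

Compound 1 and compound 4 are both reported only as limits of the assay, not as numbers, and the step between them cannot be read. The compounds shown leave open whether chloro in place of fluoro on an aromatic carbon shifts the read-out at all, and in which direction.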